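Variation of the amide substituent on the shared core

The compounds below may be only part of what the source reports. "The series", "measured", "known", "first", "only" and "open" are said of these compounds alone.

The three measured compounds share one core and differ only in the group on the amide-type nitrogen. Compound 1 `CCCCNC(=O)c1c(O)c2cccnc2n(-c2ccccc2)c1=O` carries butyl there and in a functional assay on the whole organism for inhibition, with Rattus norvegicus as the target, read by paw edema, at a dose of 100 mg/kg by the oral route (on this read-out lower numbers stand for less inhibition and higher numbers for more inhibition at the one dose given (going by the name of the read-out)), compound 1 gives 12.8%. Compound 2 `COc1cccc(NC(=O)c2c(O)c3cccnc3n(-c3ccccc3)c2=O)c1` gives 5.7%, and compound 3 `COc1ccccc1NC(=O)c1c(O)c2cccnc2n(-c2ccccc2)c1=O` gives 8.1%. Among these three numbers compound 3 stands second highest, though every gap is within the scatter: a number 7.1 percentage points lower from compound 1 to compound 2 (within the scatter), a number 4.7 percentage points lower from compound 1 to compound 3 (within the scatter) and a number 2.4 percentage points higher from compound 2 to compound 3 (within the scatter).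

Compound 4 `O=C(Nc1cnccn1)c1c(O)c2cccnc2n(-c2ccccc2)c1=O` differs from compound 3 in one place: pyrazin-2-yl in place of 2-methoxyphenyl on an amide-type nitrogen. The step most directly bearing on this is the exchange between the two methoxyphenyl groups on the same nitrogen, and the two exchanges of butyl for a methoxyphenyl also bear on it; none of them moved the read-out beyond the scatter. No step beyond the scatter in this assay is therefore expected here, in either direction. For compound 4 the expected step is a number 0.1 percentage points lower from compound 3 to compound 4 (within the scatter). Compound 4 is estimated at 8%, within 0% to 18%.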

Compound 4, a percentage reported as inhibition, in the whole organism at one dose (the size of the read-out at that dose, not a potency): 29.6%
Compound 4: the middle estimate sits 21.6 percentage points below what was measured, outside the stated range (above it).
By their numbers in this assay, from the lowest: compounds 2, 3 and 1 (each within the scatter of the next); then compound 4.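

Working notes on the amide-type nitrogen: this is the first change in the series to move this assay beyond the scatter, with pyrazin-2-yl in place of 2-methoxyphenyl giving a number 21.5 percentage points higher from compound 3 to compound 4 (beyond the scatter) and pyrazin-2-yl in place of 3-methoxyphenyl giving a number 23.9 percentage points higher from compound 2 to compound 4 (beyond the scatter). The exchange for butyl points the same way (a number 16.8 percentage points higher from compound 1 to compound 4 (beyond the scatter)), so the higher number appears against all three earlier groups, whereas those groups stayed within the scatter of one another. Nothing at hand bears on why pyrazin-2-yl stands apart from these groups.

From the compounds shown here alone, it remains open how pyridin-2-yl, whose ring holds a single nitrogen, or unsubstituted phenyl would read on this nitrogen. Also open, going by these compounds, is whether the pyrazin-2-yl result would survive an added amine or methoxy group on that ring.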